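A few compounds are considered here, and "the series" means these few. Any claim that something is new, unique, unknown or untested is made for them only; others in the source may bear on it.

Two compounds sharing one core have so far been examined in an ADME assay on MDCK cells (Canis lupus familiaris) for cytotoxicity, read by MTT assay; on this read-out higher numbers stand for lower toxicity in this test and lower numbers for higher toxicity in this test. Compound 1 `O=c1cc(-c2cccc(Cl)c2)oc2ccccc12` gives 174000 nM, the top of the two numbers, though that carries little weight, since compound 2 `O=c1cc(-c2ccc(Cl)cc2)oc2ccccc12` gives 115000 nM in this assay, and the gap lies within the scatter of repeated measurements. Compound 3 `COc1cccc(-c2cc(=O)c3ccccc3o2)c1` has not yet been measured. It differs from compound 1 in one place: methoxy in place of chloro on an aromatic carbon. Going by the values given here, no step between measured compounds covers this change, so the expected step of a 1.1-fold lower number from compound 1 to compound 3 (0.04 log units; within the scatter) is judged to stay within the scatter, with no clear direction. Compound 3 is therefore expected to give 160000 nM in this assay, between 70000 nM and 380000 nM.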

Compound 3, half-maximal cytotoxic concentration: 263000 nM
Compound 3: middle estimate off by 1.6-fold (0.22 log units), on the low side; measured number inside the range.
By their numbers in this assay, from the lowest: compounds 2, 1 and 3 (each within the scatter of the next, the first and the last beyond it).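

In this assay, methoxy in place of chloro on an aromatic carbon, meta to a large group, gives a 1.5-fold higher number from compound 1 to compound 3 (0.18 log units; within the scatter). This first step read at this position therefore shows that the exchange, which adds a hydrogen-bond acceptor, leaves the number within the scatter, with no clear direction. No measurement at hand bears on this result. On these data alone, whether an amine, a carboxylic acid or a longer chain at this position would move the number beyond the scatter remains open.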